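The compounds below may be only part of what the source reports. "The series", "measured", "known", "first", "only" and "open" are said of these compounds alone.

In an assay on isolated protein for inhibition of DNA topoisomerase 1 (Homo sapiens), with a stated time of 30 min, tested at 100 uM (on this read-out lower numbers stand for a weaker effect and higher numbers for a stronger effect at the one concentration tested), three compounds have been measured:
compound 1, `O=C(CN1CCN(c2cc3c(cc2F)c(=O)c(C(=O)O)cn3C2CC2)CC1)Nc1ccc(C(=O)/C=C/c2cccc(Cl)c2)cc1`, gives 68.8%;
compound 2, `COc1cc(/C=C/C(=O)c2ccc(NC(=O)CN3CCN(c4cc5c(cc4F)c(=O)c(C(=O)O)cn5C4CC4)CC3)cc2)cc(OC)c1OC`, gives 67.4%;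
compound 3, `O=C(CN1CCN(c2cc3c(cc2F)c(=O)c(C(=O)O)cn3C2CC2)CC1)Nc1ccc(C(=O)/C=C/c2cccc([N+](=O)[O-])c2)cc1`, gives 90.5%.

Compound 3 stands highest of the three: the steps of a number 21.7 percentage points higher from compound 1 to compound 3 (beyond the scatter) and a number 23.1 percentage points higher from compound 2 to compound 3 (beyond the scatter) both lie beyond the scatter, whereas a number 1.4 percentage points lower from compound 1 to compound 2 (within the scatter) does not. Compound 4, `Cc1ccc(/C=C/C(=O)c2ccc(NC(=O)CN3CCN(c4cc5c(cc4F)c(=O)c(C(=O)O)cn5C4CC4)CC3)cc2)c(C)c1`, is not yet measured; it differs from compound 3 by 2,4-dimethylphenyl in place of 3-nitrophenyl on a double-bonded chain carbon bound to a double-bonded chain carbon. Both steps into compound 3 bear on this change, since 3-chlorophenyl and 3,4,5-trimethoxyphenyl, each without a nitro, sit within the scatter of each other, and 2,4-dimethylphenyl also carries no nitro. A downward step, roughly reversing a number 21.7 percentage points higher from compound 1 to compound 3 (beyond the scatter), is therefore expected: a number 23.5 percentage points lower from compound 3 to compound 4 (beyond the scatter). Compound 4 is estimated at 67%, within a range from 52% to 82%.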

Compound 4, a percentage reported as inhibition, at one concentration (the size of the read-out at that concentration, not a potency) in the DNA topoisomerase 1 assay: 85.1%
Compound 4: the middle estimate sits 18.1 percentage points below what was measured; the whole stated range lies below it.
By their numbers in the DNA topoisomerase 1 assay, from the lowest: compounds 2 and 1 (each within the scatter of the next); then compounds 4 and 3 (each within the scatter of the next).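

In the DNA topoisomerase 1 assay, a nitro group proves unnecessary for the higher numbers at this place: a number 5.4 percentage points lower from compound 3 to compound 4 (within the scatter), while a number 17.7 percentage points higher from compound 2 to compound 4 (beyond the scatter) and a number 16.3 percentage points higher from compound 1 to compound 4 (beyond the scatter). Thus 2,4-dimethylphenyl, which has no hydrogen-bond acceptors, stands with 3-nitrophenyl and apart from 3-chlorophenyl and 3,4,5-trimethoxyphenyl. The same change does separate the two compounds in a physicochemical assay for solubility, at pH 7.8 (on this read-out lower numbers stand for lower solubility and higher numbers for higher solubility), where compound 3 gives 27.4 ug/mL and compound 4 gives 2.07 ug/mL: the measured solubility of compound 3, 27.4 ug/mL, and of compound 4, 2.07 ug/mL, a 13-fold lower number (1.12 log units; beyond the scatter)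

Which feature of the two aryl groups keeps the inhibition high remains open. So does whether an aminophenyl group would keep that inhibition while staying nearer the solubility of compound 3.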